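The source may report more compounds than this note shows. Statements on the series, on what has been measured and on what is new or still open speak of the compounds shown alone.

Measured in an ADME assay on microsomes from liver (Homo sapiens) for metabolic stability, read by LC-MS, with a stated time of 30 min, tested at 1 uM; a higher number here means that more of the compound is left, a lower number that less of the compound is left:
- compound 1 `O=C(NCc1ccc(S(=O)(=O)N2CCCCC2)cc1)c1cc2cnccc2s1`: 15%
- compound 2 `O=C(NCc1ccc(S(=O)(=O)N2CCCCC2)cc1)c1cc2cnccc2o1`: 46%
- compound 3 `O=C(NCc1ccc(S(=O)(=O)N2CCCCC2)cc1)c1ccn2ccnc2c1`: "not determined" (no result reported)

Compound 3 therefore has no place on the numbers and offers no starting value. Compound 4 `O=C(NCc1ccc(S(=O)(=O)N2CCCCC2)cc1)c1ccn2cncc2c1` holds the same atoms as compound 3, joined differently: a group of 9 heavy atoms (7 carbon, 2 nitrogen; one five-membered aromatic ring with 2 hetero atoms, one six-membered aromatic ring with 1 hetero atom) in place of a group of 9 heavy atoms (7 carbon, 2 nitrogen; one five-membered aromatic ring with 2 hetero atoms, one six-membered aromatic ring with 1 hetero atom), on a carbonyl carbon. The exchange lies on a carbonyl carbon whose other neighbours are: amide-type nitrogen.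

For the measured compounds named here, only one measured step bears on this change: a number 31 percentage points higher from compound 1 to compound 2 (beyond the scatter). That large step, beyond the scatter, arose at the same place, so this assay can respond strongly to an exchange there. It replaces one atom with another, however, whereas compound 4 only rejoins the atoms of compound 3. Going by the values given here, with no value for compound 3, no step of any particular size or direction can be expected. The expectation instead rests on the span from compound 1 at 15% to compound 2 at 46%, widened on both sides. The value expected for compound 4 is 35%, with an estimated range from 12% to 65%.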

Compound 4, percent of the compound remaining: 54%
Compound 4: the middle estimate sits 19 percentage points below what was measured; the measured number falls inside the stated range.
By their numbers in this assay, from the lowest: compound 1; then compounds 2 and 4 (each within the scatter of the next).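

In this assay, the place on the carbonyl carbon responds to a second exchange: the group with two nitrogen atoms gives a number 39 percentage points higher from compound 1 to compound 4 (beyond the scatter), so a large step is no longer confined to the oxygen-containing group, while a number 8 percentage points higher from compound 2 to compound 4 (within the scatter) leaves those two groups indistinguishable here. From the compounds shown here alone, compound 3 has no number, so the rejoining of the same atoms cannot be read, and the effect of that arrangement remains unknown. Nothing at hand accounts for the gains over the sulfur-containing group.

All the exchanges shown lie on this one carbonyl carbon, so the contribution of the rest of the shared core stays open. Going by these compounds, it is also open whether a methyl group or a fluorine atom on the group with two nitrogen atoms would move the number in this assay.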